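This account rests on a few compounds, and the source may have more. Where it says the series, first, only, none or still open, it means among the compounds named here.

Within the data shown here, compound 1 `O=c1nc(-c2ccccc2)c2cc(-c3ccccc3F)ccc2[nH]1` is the only member of this set that gives an actual number in an ADME assay on THP-1 cells (Homo sapiens) for cytotoxicity, read by MTT assay, with a stated time of 72 h; on this read-out higher numbers stand for an effect only at larger amounts of compound and lower numbers for an effect already at smaller amounts: compound 1 gives 50000 nM. Compound 2 `O=c1nc(-c2ccccc2)c2ccc(-c3cccnc3)cc2[nH]1` reaches only a limit of the assay in this assay, > 50000 nM. Compound 3 `O=c1nc(-c2ccccc2)c2ccc(-c3ccc(F)cc3)cc2[nH]1` likewise reaches only a limit in this assay, > 50000 nM. Among the measured compounds shown here, the single step between measured compounds, a step that the two limits leave unreadable from compound 2 to compound 3, cannot be read because of the limit of > 50000 nM in this assay, at which 2 of the 3 values shown sit. Compound 4 `CN1CCN(c2ccc3[nH]c(=O)nc(-c4ccccc4)c3c2)CC1` differs from compound 1 by 4-methylpiperazin-1-yl in place of 2-fluorophenyl on an aromatic carbon. For the measured compounds named here, no measured step matches this change, so the writer expects compound 4 to stay close to compound 1, with a step of no change at the digits printed from compound 1 to compound 4 (within the scatter) expected to lie within the scatter. Compound 4 is therefore estimated at 50000 nM, between 20000 nM and 100000 nM.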

Compound 4, half-maximal effective concentration: > 50000 nM
Compound 4: only a limit was reported (the forecaster's own chance of this, stated with the estimate: 55%); the middle value sits exactly at the limit.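

In this assay, 4-methylpiperazin-1-yl in place of 2-fluorophenyl gives a number no lower from compound 1 to compound 4 (the limit leaves the size open). Compound 4 reaches only a limit of the assay, > 50000 nM. This aromatic carbon thus takes a six-membered non-aromatic ring as well as an aromatic one with no move to lower numbers, but the size of the step cannot be read because the values gather at one limit: the limit of > 50000 nM in this assay, at which 3 of the 4 values shown sit.

From the compounds shown here alone, it remains open whether a carboxylic acid or a primary amine on this aromatic carbon would give a lower number in this assay.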